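Bromo in Place of Methyl: Expected Read-out for Compound 4

The compounds below may be only part of what the source reports. "The series", "measured", "known", "first", "only" and "open" are said of these compounds alone.

Compound 1 `Cc1ccc(NC(=O)N[C@H](C)c2ccccc2)cc1` gives 100% in an ADME assay on the whole organism with Oryza sativa as the target, tested at 0.1 uM; a lower number here means a stronger effect, a higher number a weaker effect of the compound at the concentration tested.
Compound 2 `Cc1ccc(NC(=O)N[C@@H](C)c2ccccc2)cc1` gives 100% in this assay.
Compound 3 `COc1cccc(NC(=O)N[C@@H](C)c2ccccc2)c1` gives 101% in this assay.

Compound 2 stands level with compound 1, the two together the lowest of the three numbers, and compound 3 lies within the scatter of it. Going by the values given here, the single measured step, no change at the digits printed from compound 1 to compound 2 (within the scatter), rests on (the fact that compounds 1 and 2 differ only in the configuration as drawn). Compound 4 `C[C@H](NC(=O)Nc1ccc(Br)cc1)c1ccccc1` differs from compound 2 by bromo in place of methyl on an aromatic carbon. Among the compounds with values here, no measured step exchanges one substituent for another, so the stereo step gives no direct guide to this change. With all three numbers within the scatter of one another, compound 4 is expected to give 100%, between 88% and 110%. The step of no change at the digits printed from compound 2 to compound 4 (within the scatter) is therefore expected to stay within the scatter.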

Compound 4, a percentage reported as activity, at one concentration (the size of the read-out at that concentration, not a potency): 98%
Compound 4: the middle estimate sits 2 percentage points above what was measured; measured number inside the range.
By their numbers in this assay, from the lowest: compounds 4, 1, 2 and 3 (each within the scatter of the next).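

Going by these compounds alone, at this position, on an aromatic carbon of the six-membered ring and para to a large group, the compounds now include an exchange of one substituent for another, which the earlier compounds lacked. In this assay bromo in place of methyl gives a number 2 percentage points lower from compound 2 to compound 4 (within the scatter), so this exchange leaves the read-out within the scatter. Nothing on record offers an account of this step.

On these data alone, whether an amine, a carboxylic acid or a longer chain at this position would leave the read-out within the scatter stays open. So does the reading of bromo with the stereocentre drawn the other way.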